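Exchanging one halogenated aryl ring for another on a piperazine

The source may hold more compounds than are shown below. What is called first, only, known or untested is meant among the compounds shown, and "the series" means these compounds.

Measured so far:
compound 1 `COc1ccc(N2CCN(Cc3csc(N)c3C(=O)c3ccc(Cl)cc3)CC2)cc1` gives -15%
compound 2 `Nc1scc(CN2CCN(c3ccccc3C(F)(F)F)CC2)c1C(=O)c1ccc(Cl)cc1` gives -39%
compound 3 `Nc1scc(CN2CCN(c3ccc(F)cc3F)CC2)c1C(=O)c1ccc(Cl)cc1` gives -66%

These three compounds share one core and differ only in the aryl ring attached to the ring nitrogen of the piperazine. In a functional assay on CHO cells with adenosine receptor A1 (Homo sapiens) as the target, read by cAMP accumulation and immunoassay, with a stated time of 6 min, tested at 1 uM (on this read-out lower numbers stand for a stronger effect and higher numbers for a weaker effect at the one concentration tested), compound 3 stands lowest of the three numbers; the nearest is compound 2, with a number 27 percentage points lower from compound 2 to compound 3 (beyond the scatter), and the furthest is compound 1, with a number 51 percentage points lower from compound 1 to compound 3 (beyond the scatter). Both steps lie beyond the scatter, so compound 3 shows the strongest effect among the measured set.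

Compound 4 `Nc1scc(CN2CCN(c3ccc(F)c(Cl)c3)CC2)c1C(=O)c1ccc(Cl)cc1` has not yet been measured. It differs from compound 3 in one place: 3-chloro-4-fluorophenyl in place of 2,4-difluorophenyl on an amine nitrogen in a ring. Among the compounds with values here, no measured step swaps one halogen-bearing ring for another, so none bears directly on this change. The closest guide is that compound 2 and compound 3, the two compounds carrying fluorine or trifluoromethyl, both give lower numbers than compound 1, which carries 4-methoxyphenyl, with a number 24 percentage points lower from compound 1 to compound 2 (beyond the scatter) and a number 51 percentage points lower from compound 1 to compound 3 (beyond the scatter). Compound 4 keeps one fluorine and adds a chlorine, so it is expected to remain in the range of compound 2 and compound 3, and the step is estimated at a number 11 percentage points higher from compound 3 to compound 4 (beyond the scatter). Compound 4 is therefore expected to give about -55%, within a range from -80% to -25%.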

Compound 4, a percentage reported as activity, at one concentration (the size of the read-out at that concentration, not a potency): -60%
The estimate for compound 4 lay 5 percentage points above the measured number, within the range that was stated.
By their numbers in this assay, from the lowest: compounds 3 and 4 (each within the scatter of the next); then compound 2; then compound 1.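

In this assay, replacing 2,4-difluorophenyl with 3-chloro-4-fluorophenyl on the amine nitrogen in the ring gives a result that cannot be told apart from repeat-measurement noise (a number 6 percentage points higher from compound 3 to compound 4 (within the scatter)), so this position tolerates this particular exchange of one halogen-bearing ring for another. Within the data shown here, the earlier compounds showed only that changing the ring moved the number, whereas compound 4 shows that two different rings can give results within the scatter of each other, while both the 2-(trifluoromethyl)phenyl and 4-methoxyphenyl compounds remain clearly separated from compound 4 (a number 21 percentage points lower from compound 2 to compound 4 (beyond the scatter); a number 45 percentage points lower from compound 1 to compound 4 (beyond the scatter)). Nothing available explains why compound 3 and compound 4 match.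

The compounds shown leave open whether the number would hold with an amine or a carboxylic acid on the ring, or with a plain alkyl chain in place of the ring. With a single tested concentration, they also leave open whether compound 3 and compound 4 would still match across a range of concentrations.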